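Swapping the outer aromatic ring: what happens to solubility

This account rests on a few compounds, and the source may have more. Where it says the series, first, only, none or still open, it means among the compounds named here.

Measured so far:
compound 1, `COc1ccc(-c2ccc(OCc3cc(C(=O)NS(=O)(=O)c4c(C)noc4C)oc3C)cc2)nc1`: 90 ug/mL
compound 2, `Cc1oc(C(=O)NS(=O)(=O)c2ccccc2)cc1COc1ccc(-c2ccccc2)cc1`: 2 ug/mL
compound 3, `Cc1noc(C)c1S(=O)(=O)NC(=O)c1cc(COc2ccc(-c3ccc(OC(F)F)cc3)cc2)c(C)o1`: < 0.6 ug/mL

In a physicochemical assay for solubility, in phosphate buffer, with a stated time of 24 h, at pH 7.4 (a higher number here means a more soluble compound, a lower number a less soluble compound), compound 1 gives 90 ug/mL, the highest of the three numbers. Compound 2 gives 2 ug/mL in this assay. For compound 3 only a limit is known, (the limit of < 0.6 ug/mL in this assay, at which 1 of the 3 values shown sits), so its true solubility may lie anywhere beneath it.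

Compound 4, `COc1ccc(-c2ccc(OCc3cc(C(=O)NS(=O)(=O)c4c(C)noc4C)oc3C)cc2)c(C)c1`, is not yet measured in this assay. It differs from compound 3 in one place: 4-methoxy-2-methylphenyl in place of 4-(difluoromethoxy)phenyl on an aromatic carbon.

Going by the values given here, only one measured step touches this part of the molecule: an at least 150-fold lower number from compound 1 to compound 3 (2.17 log units; beyond the scatter). That step ran from the methoxy-bearing ring of compound 1 to the difluoromethoxy-bearing ring of compound 3. The change to compound 4 brings a methoxy group back, though on a ring of carbon only and with an added methyl, so compound 1 is not an exact match. A rise from the limit of compound 3 is expected, but a smaller one than the full return to compound 1. The estimated step is an at least 8.3-fold higher number from compound 3 to compound 4 (0.92 log units; beyond the scatter), and compound 4 is expected to give about 5 ug/mL, within 0.6 ug/mL to 40 ug/mL.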

Compound 4, solubility: 200 ug/mL
Beside the measured number, compound 4's estimate is 40-fold (1.60 log units) below it; measured number outside the range, above it.
By their numbers in this assay, from the lowest: compound 2; then compound 1; then compound 4. At a limit, below all of these: compound 3.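

In this assay, compound 3 stands only at a limit, not at a true number: the limit of < 0.6 ug/mL in this assay, at which 1 of the 4 values shown sits. Even so, the change to 4-methoxy-2-methylphenyl in place of 4-(difluoromethoxy)phenyl gives a large step, an at least 330-fold higher number from compound 3 to compound 4 (2.52 log units; beyond the scatter), and both groups are six-membered aromatic rings of carbon only, so the low reading of compound 3 does not go with every ring of that kind at this position. Nor does a high number here need the 5-methoxypyridin-2-yl ring of compound 1: replacing that ring with 4-methoxy-2-methylphenyl gives a modest rise, a 2.2-fold higher number from compound 1 to compound 4 (0.35 log units; beyond the scatter), which shows that a ring of carbon only can match and slightly pass it.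

The step to compound 4 makes two changes at once, exchanging difluoromethoxy for methoxy and adding a methyl, and the compounds shown cannot separate their shares or give a reason for the size of the step. Going by these compounds, how the number would move with a nitrile, an amine or a carboxylic acid on this outer ring also remains open.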